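Chalcone series on a chromene core: antiproliferative data

The source may report more compounds than this note shows. Statements on the series, on what has been measured and on what is new or still open speak of the compounds shown alone.

Measured compounds:
compound 1, `COc1ccc(C(=O)/C=C/c2cc(OC)c(OC)c(OC)c2)c2c1C=CC(C)(C)O2`: 9700 nM
compound 2, `COc1cc(OC)c(OC)cc1/C=C/C(=O)c1ccc(OC)c2c1OC(C)(C)C=C2`: > 10000 nM
compound 3, `COc1ccc(C(=O)/C=C/c2ccc(N(C)C)cc2)c2c1C=CC(C)(C)O2`: 2750 nM

In a functional assay on SK-OV-3 cells (Homo sapiens) for antiproliferative activity, read by MTT assay, with a stated time of 24 h (on this read-out higher numbers stand for weaker inhibition and lower numbers for stronger inhibition), compound 1 gives 9700 nM. For compound 2 the assay reports only a limit, > 10000 nM, and (the limit of > 10000 nM in this assay, at which 1 of the 3 values shown sits). Compound 3 gives 2750 nM in this assay, the lowest of the two numbers on hand; compound 1 is the nearest and sits clearly higher, beyond the scatter. With compound 2 resolved only as a limit, nothing more can be said of its standing against compound 3.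

Compound 4, `COc1ccc(C(=O)/C=C/c2ccc(O)c(Br)c2)c2c1C=CC(C)(C)O2`, is not yet measured. Relative to compound 3 the change is 3-bromo-4-hydroxyphenyl in place of 4-(dimethylamino)phenyl on a double-bonded chain carbon bound to a double-bonded chain carbon. Going by the values given here, no single-point step between measured compounds is available, so the size of this change has no precedent here. The step from compound 3 to compound 4 in this assay is expected to be small, toward weaker inhibition, and may well fall inside the scatter: a 1.5-fold higher number from compound 3 to compound 4 (0.16 log units; within the scatter). Compound 4 is estimated at 4000 nM in this assay, between 1500 nM and 12000 nM.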

Compound 4, half-maximal inhibitory concentration: > 10000 nM
Compound 4: only a limit was reported; the forecaster's own chance of this, stated with the estimate: 15%; middle value at least 2.5-fold (0.39 log units) from the limit.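

In this assay, going by these compounds alone, 3-bromo-4-hydroxyphenyl in place of 4-(dimethylamino)phenyl on a double-bonded chain carbon bound to a double-bonded chain carbon gives an at least 3.6-fold higher number from compound 3 to compound 4 (0.56 log units; beyond the scatter), the first single-place step. The position is thus shown to respond to the choice of aryl group, and this exchange gives up the activity of the dimethylamino compound rather than leaving it in place. The step has only a lower bound, and the full size of the loss cannot be read: the limit of > 10000 nM in this assay, at which 2 of the 4 values shown sit.

The compounds shown do not separate the bromine from the hydroxyl of the entering group, which a phenyl ring carrying only one of the two would do. As far as these compounds go, whether the dimethylamino group itself is needed also stays open, and a primary amine or a morpholine at this place would bear on that.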